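Capping the Piperazine: Carbamoyl in Place of Hydrogen

The source may hold more compounds than are shown below. What is called first, only, known or untested is meant among the compounds shown, and "the series" means these compounds.

Compound 1 `c1ccc2c(c1)CN[C@H](CN(CCCN1CCNCC1)[C@H]1CCCc3cccnc31)C2` gives 1150 nM in a functional assay on CCRF-CEM cells for antagonist activity at C-X-C chemokine receptor type 4 (Homo sapiens), read by calcium flux, with stated times of 25 min and 90 s; a higher number here means a weaker inhibitor, a lower number a stronger inhibitor.
Compound 2 `c1ccc2c(c1)CN[C@@H](CN(CCCN1CCNCC1)[C@H]1CCCc3cccnc31)C2` gives 17 nM in this assay.
Compound 3 `c1cnc2c(c1)CN[C@@H](CN(CCCN1CCNCC1)[C@H]1CCCc3cccnc31)C2` gives 171 nM in this assay.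

Compound 2 stands lowest of the three, with compound 3 nearest and compound 1 furthest. The step of a 68-fold lower number from compound 1 to compound 2 (1.83 log units; beyond the scatter) rests on (the fact that compounds 1 and 2 differ only in the configuration as drawn), and the step of a 10-fold higher number from compound 2 to compound 3 (1.00 log units; beyond the scatter) comes from the change in the aromatic ring of the core. Compound 4 `NC(=O)N1CCN(CCCN(C[C@H]2Cc3ccccc3CN2)[C@H]2CCCc3cccnc32)CC1` differs from compound 2 by carbamoyl in place of hydrogen on an amine nitrogen in a ring. Neither measured step touches the piperazine nitrogen, so none bears directly on this change. With no guide from the measured steps, compound 4 is expected to give 60 nM in this assay, within 15 nM to 250 nM, a step of a 3.5-fold higher number from compound 2 to compound 4 (0.55 log units; beyond the scatter) that is estimated, not known.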

Compound 4, half-maximal inhibitory concentration: 959 nM
Compound 4: middle estimate off by 16-fold (1.20 log units), on the low side; the measured number lies above the stated range.
By their numbers in this assay, from the lowest: compound 2; then compound 3; then compounds 4 and 1 (each within the scatter of the next).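

Among the compounds shown here, the piperazine nitrogen, which none of the earlier steps touched, turns out to matter for this series: carbamoyl in place of its hydrogen gives a 56-fold higher number from compound 2 to compound 4 (1.75 log units; beyond the scatter). So this ring nitrogen does not accept every group, and the strong value of compound 2 does not carry over to its carbamoyl counterpart. Nothing at hand explains the size of this step.

The compounds shown leave open whether the loss is specific to carbamoyl or follows any group on this nitrogen. A smaller group such as methyl, or an acetyl group, could help tell these apart.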